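The source may hold more compounds than are shown below. What is called first, only, known or untested is meant among the compounds shown, and "the series" means these compounds.

In a functional assay on A549 cells (Homo sapiens) for cytotoxicity, read by XTT assay, with a stated time of 72 h (on this read-out lower numbers stand for stronger inhibition and higher numbers for weaker inhibition), compound 1 (`COc1cc(C(OC(C)=O)c2ccc3c(ccn3C)c2)cc(OC)c1OC`) gives > 10000 nM as a limit of the assay, not as a number. Compound 2 (`CCn1ccc2cc(/C(=N\O)c3cc(OC)c(OC)c(OC)c3)ccc21`) gives > 10000 nM, also a limit. It therefore stands at the limit of > 10000 nM in this assay, at which 2 of the 2 values shown sit. Compound 3 (`CCn1ccc2cc(/C(=N\N)c3cc(OC)c(OC)c(OC)c3)ccc21`) has amino in place of hydroxy on a double-bonded nitrogen, a change counted as amino in place of hydroxy on a double-bonded nitrogen. Among the compounds with values here, no measured step shows the effect of this swap, so no shift beyond the scatter is expected in this assay, the estimated step being a step that the limit leaves unreadable from compound 2 to compound 3 in no firm direction. For compound 3 the estimated value is 12000 nM, with an expected range from 3000 nM to 40000 nM.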

Compound 3, half-maximal inhibitory concentration: > 10000 nM
Compound 3 gave a limit, no number; the forecaster's own chance of this, stated with the estimate: 70%; the middle value lies beyond the limit too.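

In this assay compound 2 and compound 3 both stop at a limit, not a number, so no step between them can be read: the limit of > 10000 nM in this assay, at which 3 of the 3 values shown sit.

The compounds shown leave open whether amino or hydroxy on a double-bonded nitrogen makes any difference to cytotoxicity.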